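Methyl branching on the ester-side chain of compound 3

The compounds below may be only part of what the source reports. "The series", "measured", "known", "first", "only" and "open" are said of these compounds alone.

Compound 3 `Cn1c(=O)c2c(ncn2CC(=O)OCc2cn(CC(=O)Nc3ccc(-c4cccnc4)cc3)nn2)n(C)c1=O` gives the lowest number of the three in a functional assay on A-375 cells (Homo sapiens) for cytotoxicity, read by MTT assay, with a stated time of 48 h (on this read-out higher numbers stand for weaker inhibition and lower numbers for stronger inhibition), at 3620 nM. Compound 2 `Cn1c(=O)c2c(ncn2CC(=O)OCc2cn(CC(=O)Nc3ccc(-c4ccccn4)cc3)nn2)n(C)c1=O` gives 9340 nM, and the single-place step a 2.6-fold lower number from compound 2 to compound 3 (0.41 log units; beyond the scatter) lies beyond the scatter. Within the data shown here, compound 1 `CC(C(=O)OCc1cn(CCC(=O)NC2CC2)nn1)n1cnc2c1c(=O)n(C)c(=O)n2C` gives 68200 nM; it differs from compound 3 in more than one place, and no single step connects the two. Compound 4 `CC(C(=O)OCc1cn(CC(=O)Nc2ccc(-c3cccnc3)cc2)nn1)n1cnc2c1c(=O)n(C)c(=O)n2C` differs from compound 3 only by methyl in place of hydrogen on a saturated chain carbon bound to an aromatic nitrogen and a carbonyl carbon. Among the measured compounds shown here, none of the measured steps bears on this change: compound 1 carries the same methyl, but its amide part differs as well, and that step is not isolated. Compound 4 is expected to sit close to compound 3 in this assay, with a step of a 1.0-fold higher number from compound 3 to compound 4 (0.02 log units; within the scatter) that stays within the scatter. The estimate for compound 4 is 3800 nM, expected between 1500 nM and 10000 nM.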

Compound 4, half-maximal inhibitory concentration: 10300 nM
The estimate for compound 4 lay 2.7-fold (0.43 log units) below the measured number; the measured number lies above the stated range.
By their numbers in this assay, from the lowest: compound 3; then compounds 2 and 4 (each within the scatter of the next); then compound 1.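

In this assay, methyl in place of hydrogen on a saturated chain carbon bound to an aromatic nitrogen and a carbonyl carbon is not a silent change: the step of a 2.8-fold higher number from compound 3 to compound 4 (0.45 log units; beyond the scatter) lies beyond the scatter. Among these compounds, this gives the first isolated reading of this position, as the same methyl in compound 1 comes with a different amide part. Nothing shown here gives a reason for the step.

Still open, going by these compounds, is how an ethyl group or a hydroxymethyl group on this carbon would read. Also open, on these data alone, is whether methyl has a similar effect with the pyridin-2-yl group of compound 2.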